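Double-Bond Geometry in a Thromboxane Synthase Inhibitor Series

This account rests on a few compounds, and the source may have more. Where it says the series, first, only, none or still open, it means among the compounds named here.

Measured compounds:
compound 1, `C=C(C)C(CCC/C=C(\c1ccccc1)c1cccnc1)C(=O)O`, 28 nM
compound 2, `C/C(=C\CCCCC(=O)O)c1cccnc1`, 210 nM

In an assay (Equus caballus) for inhibition of Thromboxane-A synthase (Homo sapiens), using microsomes (a lower number here means a stronger inhibitor, a higher number a weaker inhibitor), compound 2 gives the higher of the two numbers; its nearest neighbour is compound 1, which gives 28 nM. Compound 3, `C/C(=C/CCCCC(=O)O)c1cccnc1`, keeps every atom and bond of compound 2: the two compounds have the same atoms and bonds and differ only in configuration as drawn: 1 of 1 stereo elements differ; a double bond is drawn E in compound 2 and Z in compound 3. Within the data shown here, no step between two measured compounds is known here. Compound 2 is expected to sit where its value shows, while for the pair from compound 2 to compound 3 a step of a 1.7-fold higher number from compound 2 to compound 3 (0.22 log units; within the scatter) in this assay is expected. Compound 3 is therefore estimated at 350 nM, within 70 nM to 1800 nM.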

Compound 3, half-maximal inhibitory concentration: 71 nM
For compound 3 the middle estimate is 4.9-fold (0.69 log units) above the measured one, within the range that was stated.
By their numbers in this assay, from the lowest: compound 1; then compound 3; then compound 2.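

In this assay, double-bond geometry alone changes the number at this position (a 3.0-fold lower number from compound 2 to compound 3 (0.47 log units; beyond the scatter)), with the Z form giving the lower value. The earlier compounds shown here could not show this, since compound 1 and compound 2 differ in more than one place. The step can be assigned to the double bond alone because nothing else separates the pair: the fact that compounds 2 and 3 differ only in the configuration as drawn. On these data alone, whether the Z form keeps its advantage with a longer chain, or with an amide in place of the carboxylic acid, remains open. The compounds shown also leave open whether the same preference holds for the geometry of compound 1.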